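Swapping a pyrazine for a methylphenyl: solubility outlook

The compounds below may be only part of what the source reports. "The series", "measured", "known", "first", "only" and "open" are said of these compounds alone.

Compound 1 `CCCOc1ccc(C[C@@H](Cc2ccccc2)C(=O)O)cc1CNC(=O)c1ccc(-c2cncnc2)cc1` gives 190 ug/mL in a physicochemical assay for solubility, read by HPLC, in phosphate buffer, measured as thermodynamic solubility, with a stated time of 48 h, at pH 7.2; a higher number here means a more soluble compound, a lower number a less soluble compound.
Compound 2 `CCCOc1ccc(C[C@@H](Cc2ccccc2)C(=O)O)cc1CNC(=O)c1ccc(-c2ccncc2)cc1` gives 34.1 ug/mL in this assay.
Compound 3 `CCCOc1ccc(C[C@@H](Cc2ccccc2)C(=O)O)cc1CNC(=O)c1ccc(-c2cnccn2)cc1` gives 32.2 ug/mL in this assay.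

Compound 3 has the lowest of the three numbers; its value and that of compound 2 lie within the scatter of each other, whereas compound 1 sits higher, as a 5.9-fold lower number from compound 1 to compound 3 (0.77 log units; beyond the scatter) shows. Compound 4 `CCCOc1ccc(C[C@@H](Cc2ccccc2)C(=O)O)cc1CNC(=O)c1ccc(-c2ccccc2C)cc1` differs from compound 3 by 2-methylphenyl in place of pyrazin-2-yl on an aromatic carbon. Among the measured compounds shown here, no measured step exchanges a ring with hetero atoms for a ring of carbon only, so the change is not matched directly. The steps of a 5.6-fold lower number from compound 1 to compound 2 (0.75 log units; beyond the scatter) and a 5.9-fold lower number from compound 1 to compound 3 (0.77 log units; beyond the scatter) show that changing the terminal ring can move the number modestly, while a 1.1-fold lower number from compound 2 to compound 3 (0.02 log units; within the scatter) shows it can also leave it unchanged. Compound 4 is therefore estimated to give 10 ug/mL, with a range from 3 ug/mL to 35 ug/mL, meaning an expected 3.2-fold lower number from compound 3 to compound 4 (0.51 log units; beyond the scatter), held loosely.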

Compound 4, solubility: < 1 ug/mL
Compound 4 ended at the assay's limit; the forecaster's own chance of this, stated with the estimate: 10%; middle value at least 10-fold (1.00 log units) from the limit.
By their numbers in this assay, from the lowest: compounds 3 and 2 (each within the scatter of the next); then compound 1. At a limit, below all of these: compound 4.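

Compound 4 stands at a limit of this assay, not at a number: the limit of < 1 ug/mL in this assay, at which 1 of the 4 values shown sits.

Moving to 2-methylphenyl on this aromatic carbon gives large steps from all three rings with hetero atoms: an at least 32-fold lower number from compound 3 to compound 4 (1.50 log units; beyond the scatter), an at least 34-fold lower number from compound 2 to compound 4 (1.53 log units; beyond the scatter) and an at least 190-fold lower number from compound 1 to compound 4 (2.27 log units; beyond the scatter). Exchanges among those three rings gave modest steps at most, so this position can carry a far larger drop than they revealed.

The compounds shown leave open whether the loss of the ring nitrogens or the added methyl carries this step. Going by these compounds, how a plain phenyl or a phenyl bearing an amine would read here also remains open.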